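A few compounds are considered here, and "the series" means these few. Any claim that something is new, unique, unknown or untested is made for them only; others in the source may bear on it.

Measured compounds:
compound 1 `Cc1ccc(C(=O)O[C@@H]2C[C@H](C)CC[C@H]2C(C)C)cc1` — 5.29
compound 2 `CC(C)[C@@H]1CC[C@@H](C)C[C@H]1OC(=O)c1ccc([N+](=O)[O-])cc1` — 4.78
compound 3 `Cc1ccccc1C(=O)O[C@@H]1C[C@H](C)CC[C@H]1C(C)C` — 5.29

Within the data shown here, the three esters share one core and differ only in the single group on the aromatic ring. In a physicochemical assay for lipophilicity, measured as octanol-water partition (a higher number here means a more lipophilic compound, a lower number a more polar compound), compound 3 gives 5.29, level with compound 1 at the digits shown; together these two are the highest of the three numbers. Among the measured compounds shown here, the only measured step, a number 0.51 log units lower from compound 1 to compound 2 (beyond the scatter), is a modest fall that lies beyond the scatter, and compound 3 stands the same distance above compound 2.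

Compound 4 `CC(C)[C@@H]1CC[C@@H](C)C[C@H]1OC(=O)c1ccccc1` has not yet been measured. It differs from compound 3 by hydrogen in place of methyl on an aromatic carbon. No measured pair shows this particular change: the one step on record swaps a methyl for a nitro, which is a different exchange, and compounds 1 and 3, both carrying a methyl, give the same value at the digits shown. The loss of one carbon is expected to give a small step downward in this assay, estimated as a number 0.49 log units lower from compound 3 to compound 4 (beyond the scatter). Compound 4 is therefore expected at 4.8, within a range from 4.5 to 5.1.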

Compound 4, partition coefficient: 4.82
Compound 4: middle estimate off by 0.02 log units, on the low side, within the range that was stated.
By their numbers in this assay, from the lowest: compounds 2 and 4 (each within the scatter of the next); then compounds 1 and 3 (each within the scatter of the next).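

In this assay the exchange of methyl for hydrogen on an aromatic carbon, ortho to a large group, is now read directly as a number 0.47 log units lower from compound 3 to compound 4 (beyond the scatter) and sits beyond the scatter. The same exchange read from the other methyl compound gives a number 0.47 log units lower from compound 1 to compound 4 (beyond the scatter) and so matches it in size, which means the two methyl compounds stand apart from compound 4 by the same measure. Nitro and hydrogen are not separated, with a number 0.04 log units higher from compound 2 to compound 4 (within the scatter) as the printed step, so the fall earlier seen on going to nitro is matched by losing the methyl alone.

Nothing shown explains these steps. On these data alone, whether an amine or a carboxylic acid on the ring would stay level with compound 4, or a longer chain would pass the methyl compounds, remains open.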